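The source may hold more compounds than are shown below. What is called first, only, known or untested is meant among the compounds shown, and "the series" means these compounds.

Working notes on the series. In an ADME assay on microsomes from liver (Rattus norvegicus) for metabolic stability, read by LC-MS, using NADPH, with a stated time of 30 min, tested at 1 uM (on this read-out lower numbers stand for slow clearance and higher numbers for fast clearance), compound 1 `CC(C)c1noc(N2CCC(Oc3cc(N4CCc5cc(N6CCCCC6=O)ccc54)ncn3)CC2)n1` gives 13 mL.min-1.g-1, compound 2 `CC(C)c1noc(N2CCC(Oc3cc(N4CCc5cc(N6CCCNS6(=O)=O)ccc54)ncn3)CC2)n1` gives 21 mL.min-1.g-1 and compound 3 `CC(C)c1noc(N2CCC(Oc3cc(N4CCc5cc(N6CCCS6(=O)=O)ccc54)ncn3)CC2)n1` gives 1 mL.min-1.g-1, the lowest of the three; the nearest is a 13-fold lower number from compound 1 to compound 3 (1.11 log units; beyond the scatter) and the furthest is a 21-fold lower number from compound 2 to compound 3 (1.32 log units; beyond the scatter). Compound 4 `CC(=O)N(C)c1ccc2c(c1)CCN2c1cc(OC2CCN(c3nc(C(C)C)no3)CC2)ncn1` differs from compound 3 in one place: a group of 5 heavy atoms (3 carbon, 1 nitrogen, 1 oxygen; no ring) in place of a group of 7 heavy atoms (3 carbon, 1 nitrogen, 2 oxygen, 1 sulfur; one five-membered non-aromatic ring with 2 hetero atoms), on an aromatic carbon. Both measured steps into compound 3 bear on this change, since each swaps the same group on the same aromatic carbon, and both were large, so a large step back up is expected in this assay. Compound 4 is expected to give 12 mL.min-1.g-1, with a range of 4 mL.min-1.g-1 to 35 mL.min-1.g-1, meaning an expected step of a 12-fold higher number from compound 3 to compound 4 (1.08 log units; beyond the scatter).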

Compound 4, intrinsic clearance in microsomes: 17 mL.min-1.g-1
The estimate for compound 4 lay 1.4-fold (0.15 log units) below the measured number; measured number inside the range.
By their numbers in this assay, from the lowest: compound 3; then compounds 1, 4 and 2 (each within the scatter of the next).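

In this assay, a ring is not needed at this aromatic carbon to reach the higher numbers: acetyl(methyl)amino in place of 2-oxopiperidin-1-yl stays within the scatter (a 1.3-fold higher number from compound 1 to compound 4 (0.12 log units; within the scatter)), as it does in place of the six-membered ring with 3 hetero atoms (a 1.2-fold lower number from compound 2 to compound 4 (0.09 log units; within the scatter)). Among these four compounds, the low number therefore stands with the five-membered ring of compound 3 alone, and the group with no ring does not keep it (a 17-fold higher number from compound 3 to compound 4 (1.23 log units; beyond the scatter)). Nothing measured here speaks to the reason.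

From the compounds shown here alone, whether the low number needs that ring, or would also come with an open-chain methyl(methylsulfonyl)amino group, stays open. So does where a simple amine or a carboxylic acid at this aromatic carbon would fall.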